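The compounds below may be only part of what the source reports. "The series", "measured", "known", "first", "only" and "open" are said of these compounds alone.

Measured so far in a functional assay (plasma) for inhibition, with Oryctolagus cuniculus as the target; on this read-out higher numbers stand for weaker inhibition and lower numbers for stronger inhibition:
- compound 1 `Cc1cccc(S(=O)(=O)N[C@H]2C3CC[C@H](C3)[C@@H]2C/C=C\CCCC(=O)O)c1` gives 1700 nM
- compound 2 `CCCCCc1ccc(S(=O)(=O)N[C@H]2C3CC[C@H](C3)[C@@H]2C/C=C\CCCC(=O)O)cc1` gives 800000 nM
- compound 3 `O=C(O)CCC/C=C\C[C@H]1[C@@H]2CCC(C2)[C@@H]1NS(=O)(=O)CCc1ccccc1` gives 8200 nM

Compound 1 stands with the lowest of these three numbers, and so with the strongest inhibition among them: compound 3 is its nearest neighbour, and compound 2 lies far above both. Among the compounds with values here, the only single-point step recorded runs a 4.8-fold higher number from compound 1 to compound 3 (0.68 log units; beyond the scatter); it shows that swapping the group on the sulfonyl sulfur of compound 1 costs a modest amount of potency. Compound 2, which carries a longer chain on its aromatic ring, shows a much higher number still, though it differs from compound 1 in more than one respect.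

Compound 4 `O=C(O)CCC/C=C\C[C@H]1[C@@H]2CCC(C2)[C@@H]1NS(=O)(=O)c1cccc2ccccc12` is not yet measured. It differs from compound 1 in one place: naphthalen-1-yl in place of 3-methylphenyl on a sulfonyl sulfur. Within the data shown here, no measured step covers a change of this kind, so the step from compound 1 to compound 3 is the closest guide, and it suggests that altering this group moves the number upward by a modest amount rather than leaving it unchanged. Compound 4 is therefore expected to show a 2.4-fold higher number from compound 1 to compound 4 (0.37 log units; beyond the scatter), with an estimated value of 4000 nM and a likely range from 800 nM to 20000 nM.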

Compound 4, half-maximal inhibitory concentration: 1100 nM
Beside the measured number, compound 4's estimate is 3.6-fold (0.56 log units) above it; the range from low to high includes it.
By their numbers in this assay, from the lowest: compounds 4 and 1 (each within the scatter of the next); then compound 3; then compound 2.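

Placing naphthalen-1-yl in place of 3-methylphenyl on the sulfonyl sulfur adds a second six-membered aromatic ring of carbon only, and in this assay this gives a 1.5-fold lower number from compound 1 to compound 4 (0.19 log units; within the scatter), so this position accepts the second ring with no change that can be told from scatter. Set against phenethyl, the same group gives a 7.5-fold lower number from compound 3 to compound 4 (0.87 log units; beyond the scatter), which places the phenethyl group of compound 3 apart from both aromatic groups of compounds 1 and 4, although compound 2, which also carries an aromatic ring on the sulfonyl sulfur, goes against any simple link between such a ring and a low number, giving 800000 nM. Nothing available offers a reason for these differences.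

The compounds shown leave open whether the result depends on how the second ring is joined, as naphthalen-2-yl would test, and whether a small group such as methoxy or chloro on the aromatic ring would read like the methyl of compound 1. They also leave open how short a chain on that ring must be to avoid the high number of compound 2, as an ethyl or propyl group would show.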